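The compounds below may be only part of what the source reports. "The series", "measured", "known", "first", "only" and "open" are said of these compounds alone.

Compound 1 `C[C@H]1CC[C@@H]2[C@@H](OC(=O)[C@]23CC(c2ccccc2Br)=NO3)[C@]2(C)C(=O)C=C[C@@]12O` gives 18000 nM 
Compound 2 `COc1cc(C2=NO[C@]3(C2)C(=O)O[C@@H]2[C@H]3CC[C@H](C)[C@]3(O)C=CC(=O)[C@@]23C)ccc1O` gives 71000 nM 

Going by the values given here, in a functional assay on DU-145 cells (Homo sapiens) for cytotoxicity, read by sulforhodamine B assay, with a stated time of 48 h (a higher number here means a weaker inhibitor, a lower number a stronger inhibitor), compound 2 at 71000 nM holds the higher of the two numbers, and its only neighbour is compound 1 at 18000 nM on the lower side. Compound 3 `C[C@H]1CC[C@@H]2[C@@H](OC(=O)[C@]23CC(c2ccccc2Cl)=NO3)[C@]2(C)C(=O)C=C[C@@]12O` is still unmeasured. The change from compound 2 is 2-chlorophenyl in place of 4-hydroxy-3-methoxyphenyl on a carbon with a double bond to nitrogen. Among the compounds with values here, one measured step bears on this: a 3.9-fold higher number from compound 1 to compound 2 (0.60 log units; beyond the scatter) is modest and brings in the same 4-hydroxy-3-methoxyphenyl that now leaves. Within the data shown here, compound 3 carries 2-chlorophenyl where compound 1 carries 2-bromophenyl, and no measurement yet compares those two groups. Compound 3 is therefore expected to land near compound 1 at 18000 nM and not near compound 2. What is expected in this assay is a 3.6-fold lower number from compound 2 to compound 3 (0.55 log units; beyond the scatter) toward the lower number, about the size of that one measured step and beyond the scatter. For compound 3 the estimated value is 20000 nM (expected range 7000 nM to 50000 nM).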

Compound 3, half-maximal inhibitory concentration: 19000 nM
Compound 3: the middle estimate sits 1.1-fold (0.02 log units) above what was measured; low and high end bracket the measured number.
By their numbers in this assay, from the lowest: compounds 1 and 3 (each within the scatter of the next); then compound 2.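

In this assay, a 1.1-fold higher number from compound 1 to compound 3 (0.02 log units; within the scatter) shows that, on this aromatic carbon, chloro in place of bromo leaves the number within the scatter, so these two halogens cannot be told apart here. With a 3.7-fold lower number from compound 2 to compound 3 (0.57 log units; beyond the scatter), the gap to 4-hydroxy-3-methoxyphenyl on the carbon with a double bond to nitrogen now appears against two halogen-bearing phenyl groups, 2-bromophenyl and 2-chlorophenyl, and is therefore not specific to bromo; no compound shown goes against this, though the pattern rests on compounds 1, 2 and 3 alone. No supporting data are available to explain either step.

Compound 2 carries its hydroxy and methoxy groups together, so the compounds shown cannot assign the weaker number to either group alone, or to the loss of the halogen. Also open, on these data alone, is how a phenyl with no substituent, or a phenyl bearing an amine or a carboxylic acid, would compare at this position on the shared core.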